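Swapping chloro for fluoro across two related cores

This account rests on a few compounds, and the source may have more. Where it says the series, first, only, none or still open, it means among the compounds named here.

Within the data shown here, compound 1 `Clc1ccc(-c2n[nH]cc2N2CCCNCC2)cc1` is the first of three measured compounds. In an assay on isolated protein for binding affinity to 5-hydroxytryptamine receptor 3A (Homo sapiens) (on this read-out lower numbers stand for stronger inhibition and higher numbers for weaker inhibition), compound 1 gives 498 nM. Compound 2 `Fc1ccc(-c2n[nH]cc2N2CCCNCC2)cc1` carries one change, (fluoro in place of chloro on an aromatic carbon), and in this assay compound 2 gives 1810 nM, a step of a 3.6-fold higher number from compound 1 to compound 2 (0.56 log units; beyond the scatter). Compound 3 `Clc1ccc(-c2n[nH]cc2N2CCNCC2)cc1` has a different core; how the core of compound 3 differs from the core of compound 1 is not broken down here. In this assay compound 3 gives 1790 nM, close to the number of compound 2.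

Compound 4 `Fc1ccc(-c2n[nH]cc2N2CCNCC2)cc1` has not yet been measured. It differs from compound 3 by fluoro in place of chloro on an aromatic carbon, the same change that turns compound 1 into compound 2, made at the same kind of place. A step of about a 3.6-fold higher number from compound 3 to compound 4 (0.55 log units; beyond the scatter) is expected in this assay, beside the earlier step, because compound 1 to compound 2 showed a 3.6-fold higher number from compound 1 to compound 2 (0.56 log units; beyond the scatter) and compound 3 starts from 1790 nM. On this basis compound 4 is estimated at 6400 nM, expected to fall between 2500 nM and 16000 nM.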

Compound 4, inhibition constant: > 10000 nM
Compound 4 ended at the assay's limit; the forecaster's own chance of this, stated with the estimate: 15%; at least 1.5-fold (0.19 log units) between middle value and limit.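

Fluoro in place of chloro raises the number on the second core as it did on the first, with an at least 5.5-fold higher number from compound 3 to compound 4 (0.74 log units; beyond the scatter), so in these two pairs the direction of the change carries over from one core to the other. In this assay compound 4 stands at a limit of the assay and not at a number: the limit of > 10000 nM in this assay, at which 1 of the 4 values shown sits. What these pairs do not show is whether the size of the change is the same on both cores: the same change on two cores in this assay, a 3.6-fold higher number (0.56 log units; beyond the scatter) from compound 1 to compound 2 and an at least 5.5-fold higher number (0.74 log units; beyond the scatter) from compound 3 to compound 4; the limit leaves it open whether they differ

As far as these compounds go, how much weaker compound 4 truly is than compound 3 stays unknown, and two pairs cannot say whether the same direction would hold on any further core. It also remains open how bromo, a methyl group or a plain hydrogen would compare with chloro and fluoro on that same aromatic carbon, since only these two halogens appear there in the compounds shown.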